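This account rests on a few compounds, and the source may have more. Where it says the series, first, only, none or still open, it means among the compounds named here.

Compound 1 `Cc1ccc(NCc2nc3ccc(Br)cc3[nH]2)cc1` and compound 2 `O=[N+]([O-])c1ccc2nc(CNc3ccc(Br)cc3)[nH]c2c1` share the same core. In a functional assay on the whole organism (strain albino) for inhibition, with Rattus norvegicus as the target, read by paw edema, with a stated time of 60 min, at a dose of 100 mg/kg by the oral route (a higher number here means more inhibition at the dose given (going by the name of the read-out), a lower number less inhibition), compound 1 gives 20% and compound 2 gives 20%; these two values stand level with each other within the scatter. Compound 3 `Brc1ccc2nc(CNc3ccccc3)[nH]c2c1` has not yet been measured. The change from compound 1 to compound 3 is hydrogen in place of methyl on an aromatic carbon. For the measured compounds named here, no step between measured compounds covers this change, so the numbers give no direction for it, and any step is expected to stay within the scatter. For compound 3 the value in this assay is estimated at 20%, with a range from 8% to 32%, which means an expected step of no change at the digits printed from compound 1 to compound 3 (within the scatter).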

Compound 3, a percentage reported as inhibition, in the whole organism at one dose (the size of the read-out at that dose, not a potency): 26.6%
Compound 3: middle estimate off by 6.6 percentage points, on the low side; the measured number falls inside the stated range.
By their numbers in this assay, from the lowest: compounds 1, 2 and 3 (each within the scatter of the next).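

In this assay, for the compounds shown here, hydrogen in place of methyl on the aromatic carbon, para to a large group, gives a number 6.6 percentage points higher from compound 1 to compound 3 (within the scatter) and provides the first direct reading at this position. At this single dose, the read-out stays within the scatter without the methyl, so the methyl is not required to hold this level of inhibition. Nothing measured here offers an explanation for the step.

As far as these compounds go, whether an amine or a carboxylic acid at this position would move the read-out beyond the scatter remains open. A longer chain in the same place is equally untested in the compounds shown.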